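A Pyridine Swap and Rat Half-Life

A few compounds are considered here, and "the series" means these few. Any claim that something is new, unique, unknown or untested is made for them only; others in the source may bear on it.

In an ADME assay on the whole organism (strain Sprague-Dawley) for metabolic stability, with Rattus norvegicus as the target (a lower number here means that the compound disappears faster, a higher number that the compound lasts longer), compound 3 `Cc1nc2c(s1)CC[C@H]2C(=O)Nc1ccc(C[C@@H]2CC[C@H]([C@H](O)c3ccccc3)N2)cc1` gives 1 h, level with compound 2 `O=C(Nc1ccc(C[C@@H]2CC[C@H]([C@H](O)c3ccccc3)N2)cc1)[C@@H]1CCc2scnc21` at 1 h. Together these are the lowest of the three numbers, while compound 1 `Nc1nc2c(s1)CC[C@H]2C(=O)Nc1ccc(C[C@@H]2CC[C@H]([C@H](O)c3cccnc3)N2)cc1` stands at 4 h. Compound 4 `Cc1nc2c(s1)CC[C@H]2C(=O)Nc1ccc(C[C@@H]2CC[C@H]([C@H](O)c3cccnc3)N2)cc1` departs from compound 3 by one change: pyridin-3-yl in place of phenyl on a saturated chain carbon bound to an oxygen on a saturated carbon and a saturated ring carbon. In words, pyridin-3-yl replaces phenyl on a saturated chain carbon bound to an oxygen on a saturated carbon and a saturated ring carbon. Going by the values given here, no measured step isolates this swap. Among the compounds with values here, the only measured step shows no change at the digits printed from compound 2 to compound 3 (within the scatter), for methyl in place of hydrogen on an aromatic carbon, so that change offers no sign of a large effect from the methyl. The nearest guide is compound 1 at 4 h, which also carries pyridin-3-yl but differs elsewhere, so it supports a rise only tentatively. The expected step is a 3.0-fold higher number from compound 3 to compound 4 (0.48 log units; beyond the scatter), upward in this assay. For compound 4 the estimated half-life is 3 h, with an expected range from 1.3 h to 6 h.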

Compound 4, half-life: 1 h
The estimate for compound 4 lay 3.0-fold (0.48 log units) above the measured number; the measured number lies below the stated range.
By their numbers in this assay, from the lowest: compounds 2, 3 and 4 (each within the scatter of the next); then compound 1.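

In this assay the result is no change at the digits printed from compound 3 to compound 4 (within the scatter) when pyridin-3-yl takes the place of phenyl on a saturated chain carbon bound to an oxygen on a saturated carbon and a saturated ring carbon, so with methyl on the aromatic carbon this swap gives no readable step. Compound 1 and compound 4 both carry pyridin-3-yl, yet the reading is a 4.0-fold lower number from compound 1 to compound 4 (0.60 log units; beyond the scatter) for methyl in place of amino on an aromatic carbon, which ties the higher number of compound 1 to amino at that carbon rather than to pyridin-3-yl alone. Nothing at hand gives a measured reason for either step.

The compounds shown leave open whether the swap of phenyl for pyridin-3-yl would read the same with amino on that aromatic carbon. They also leave open how an ethyl or methoxy group there would compare with amino and methyl.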